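The source may report more compounds than this note shows. Statements on the series, on what has been measured and on what is new or still open speak of the compounds shown alone.

- compound 1 `O=C(Nc1cccc(Cl)c1)c1cc(Br)cc(Br)c1O` gives 18000 nM
- compound 2 `O=C(Nc1cccc(Cl)c1)c1cc(Br)cc(Br)c1` gives 53000 nM

In an ADME assay on HEK293 cells (Homo sapiens) for cytotoxicity, read by reporter gene assay and resazurin assay, with a stated time of 48 h (a higher number here means that more compound is tolerated, a lower number that less compound is tolerated), compound 2 stands highest of the two, with 53000 nM as its value. Compound 3 `COc1c(Br)cc(Br)cc1C(=O)Nc1cccc(Cl)c1` alters compound 2 in one place: methoxy in place of hydrogen on an aromatic carbon that is, methoxy in place of hydrogen on an aromatic carbon. Within the data shown here, one measured step bears on this, a 2.9-fold higher number from compound 1 to compound 2 (0.47 log units; beyond the scatter) for hydrogen in place of hydroxy on that same carbon, and it was modest. Methoxy puts an oxygen back there, so a modest move to a lower number is expected, though nothing measured yet shows what methoxy itself does. The expected change is a 1.8-fold lower number from compound 2 to compound 3 (0.25 log units; within the scatter) in this estimate. For compound 3 the estimated value is 30000 nM with an expected range from 12000 nM to 70000 nM around it.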

Compound 3, half-maximal cytotoxic concentration: > 100000 nM
Compound 3: a limit, no number; the forecaster's own chance of this, stated with the estimate: 15%; middle value at least 3.3-fold (0.52 log units) away from the limit.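

In this assay compound 3 stands at a limit, not a number: the limit of > 100000 nM in this assay, at which 1 of the 3 values shown sits.

Putting a methyl on the oxygen gives an at least 5.5-fold higher number from compound 1 to compound 3 (0.74 log units; beyond the scatter), so an oxygen on this aromatic carbon does not by itself bring the lower number seen with the free hydroxy. Against plain hydrogen, the change gives an at least 1.8-fold higher number from compound 2 to compound 3 (0.27 log units; that floor lies within the scatter), so methoxy is at least level with hydrogen here, and the true gap could be larger.

As far as these compounds go, the true value of compound 3 stays open. So does what an amine or an ethoxy group on this same carbon would give.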